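Decylphenyl oxadiazole series: amino acid to diamine

The source may report more compounds than this note shows. Statements on the series, on what has been measured and on what is new or still open speak of the compounds shown alone.

Measured so far:
compound 1 `CCCCCCCCCCc1ccc(-c2noc(C3CCNC3)n2)cc1` — 26%
compound 2 `CCCCCCCCCCc1ccc(-c2noc(CN3CCNCC3)n2)cc1` — 19%
compound 3 `CCCCCCCCCCc1ccc(-c2noc(CC[C@@H](N)C(=O)O)n2)cc1` — 5%

In an assay on HeLa cells for inhibition of sphingosine-1-phosphate transporter SPNS2 (Mus musculus), read by LC-MS, tested at 2 uM (on this read-out higher numbers stand for more inhibition at the one concentration tested (going by the name of the read-out) and lower numbers for less inhibition), compound 3 stands lowest of the three numbers; compound 2 lies nearest and compound 1 furthest, both beyond the scatter. Compound 4 `CCCCCCCCCCc1ccc(-c2noc([C@@H](N)CCN)n2)cc1` is not yet measured. Its change from compound 3 is 1,3-diaminopropyl in place of 3-amino-3-carboxypropyl on an aromatic carbon. Among the measured compounds shown here, the steps that bear on it are a number 21 percentage points lower from compound 1 to compound 3 (beyond the scatter) and a number 14 percentage points lower from compound 2 to compound 3 (beyond the scatter), both running from a basic amine-bearing group to the amino acid and both downward. Compound 4 carries two amines and no carboxylic acid, so a step back upward of modest size is expected, a number 15 percentage points higher from compound 3 to compound 4 (beyond the scatter). For compound 4 the expected value in this assay is 20%, within 6% to 36%.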

Compound 4, a percentage reported as inhibition, at one concentration (the size of the read-out at that concentration, not a potency): 14%
Beside the measured number, compound 4's estimate is 6 percentage points above it; low and high end bracket the measured number.
By their numbers in this assay, from the lowest: compounds 3, 4, 2 and 1 (each within the scatter of the next, the first and the last beyond it).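

In this assay, 1,3-diaminopropyl in place of 3-amino-3-carboxypropyl on this aromatic carbon gives a number 9 percentage points higher from compound 3 to compound 4 (within the scatter), so exchanging the amino acid for this diamine does not clear the scatter. Against the other basic groups, the result is a number 5 percentage points lower from compound 2 to compound 4 (within the scatter) and a number 12 percentage points lower from compound 1 to compound 4 (beyond the scatter), so the open-chain diamine stays level with (piperazin-1-yl)methyl but apart from pyrrolidin-3-yl. Nothing available accounts for these steps. The compounds shown leave open how a lone primary amine, or a carboxylic acid without an amine, would read at this position.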